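The source may report more compounds than this note shows. Statements on the series, on what has been measured and on what is new or still open speak of the compounds shown alone.

Working notes, series of compound 1. In an assay on BTI-TN-5B1-4 cells for inhibition of Amine oxidase [flavin-containing] A (Homo sapiens), read by fluorescence and Amplex Red, using microsomes, with a stated time of 30 min (on this read-out lower numbers stand for stronger inhibition and higher numbers for weaker inhibition), compound 1 `C#CCOc1ccc(-c2cc(-c3ccc(OCC#C)cc3)nc(-c3ccccc3)n2)cc1` gives 25600 nM. Compound 2 `C#CCOc1ccc(-c2cc(-c3ccc(OCC#C)c(OC)c3)nc(-c3ccccc3)n2)cc1` gives 24900 nM in this assay, and the step of a 1.0-fold lower number from compound 1 to compound 2 (0.01 log units; within the scatter) lies within the scatter, so compound 1 and compound 2 stand together at the weak end of what has been measured. Compound 3 `C#CCOc1ccc(-c2cc(-c3cccc(OCC#C)c3)nc(-c3ccccc3)n2)cc1` differs from compound 1 in that (3-(propargyloxy)phenyl in place of 4-(propargyloxy)phenyl on an aromatic carbon). Among the compounds with values here, no measured step moves the propargyloxy group around its ring; the one step on record, a 1.0-fold lower number from compound 1 to compound 2 (0.01 log units; within the scatter), adds a methoxy group and leaves the number unchanged, so the shared core seems tolerant of small edits on this aryl group, though this rests on two compounds only. For compound 3 the expected step of a 1.0-fold lower number from compound 1 to compound 3 (0.01 log units; within the scatter) is therefore none beyond the scatter in this assay. Compound 3 is estimated at 25000 nM, with an expected range from 8000 nM to 80000 nM.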

Compound 3, half-maximal inhibitory concentration: 25800 nM
Compound 3: middle estimate off by 1.0-fold (0.01 log units), on the low side, within the range that was stated.
By their numbers in this assay, from the lowest: compounds 2, 1 and 3 (each within the scatter of the next).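

In this assay, exchanging 4-(propargyloxy)phenyl for 3-(propargyloxy)phenyl on this aromatic carbon gives a 1.0-fold higher number from compound 1 to compound 3 (0.00 log units; within the scatter), so the read-out does not separate these two placements of the propargyloxy group. The earlier step covered only an added methoxy group on this aryl group, whereas this one relocates the propargyloxy group itself and still leaves the number within the scatter. No supporting data bear on why the two placements read alike.

Still open, going by these compounds, is whether the propargyloxy group matters at all on this aryl group, which an amine or a hydroxyl group in its place, or a longer chain ending in the triple bond, would begin to address. Also open, on these data alone, is whether any edit to the shared core moves the number beyond the scatter.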